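Replacing a Bis(dimethylaminoethyl)amine with a Pyridylmethyl Ethylamine

The compounds below may be only part of what the source reports. "The series", "measured", "known", "first", "only" and "open" are said of these compounds alone.

The study compares three aryl sulfamates that share one core and differ only in the amine attached to the benzoyl ring. Going by the values given here, compound 1 `CN(C)CCN(CCN(C)C)c1cccc(C(=O)N2CCc3ccc(OS(N)(=O)=O)cc3C2)c1` carries a bis(2-(dimethylamino)ethyl)amino group; in an assay on HEK293 cells for inhibition of Steryl-sulfatase (Homo sapiens), tested at 1 uM (a lower number here means a weaker effect, a higher number a stronger effect of the compound at the concentration tested), compound 1 gives 17.1%, the lowest of the two numbers measured so far. Compound 2 `CCN(Cc1ccccc1)c1ccc(C(=O)N2CCc3ccc(OS(N)(=O)=O)cc3C2)cc1` carries an ethyl(benzyl)amino group, and in this assay compound 2 gives 83.6%, a number far beyond the scatter above compound 1.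

Compound 3 `CCN(Cc1cccnc1)c1cccc(C(=O)N2CCc3ccc(OS(N)(=O)=O)cc3C2)c1` has not yet been measured. It differs from compound 1 by one change: ethyl((pyridin-3-yl)methyl)amino in place of bis(2-(dimethylamino)ethyl)amino on an aromatic carbon. Among the compounds with values here, no measured pair shows this exact change, so its size is not known from the data. Given that compound 2, the only other measured compound with a smaller ethyl-bearing amine, reaches 83.6%, compound 3 is expected to lie well above compound 1, with a step of a number 42.9 percentage points higher from compound 1 to compound 3 (beyond the scatter) beyond the scatter. The estimate for compound 3 in this assay is 60%, with a range from 30% to 85%.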

Compound 3, a percentage reported as inhibition, at one concentration (the size of the read-out at that concentration, not a potency): 33.5%
Compound 3: middle estimate off by 26.5 percentage points, on the high side; the range from low to high includes it.
By their numbers in this assay, from the lowest: compound 1; then compound 3; then compound 2.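

Placing ethyl((pyridin-3-yl)methyl)amino in place of bis(2-(dimethylamino)ethyl)amino on this aromatic carbon, meta to a large group, gives a modest change in this assay (a number 16.4 percentage points higher from compound 1 to compound 3 (beyond the scatter)), which shows that the read-out responds to the amine at this position. Going by these compounds alone, the step is the only one available between compounds that differ in one place, and with compound 3 at 33.5%, this exchange of two open chains for an ethyl group and a pyridin-3-ylmethyl group does not bring the read-out to a high number at the concentration tested. Nothing in the available data accounts for the size of this step.

The compounds shown leave open which part of the entering group carries the step, whether the ethyl group, the pyridine ring or the loss of the dimethylaminoethyl chains. A morpholine or a piperidine on the same aromatic carbon, or a propyl chain in place of the ethyl group, would begin to separate these parts.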